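This account rests on a few compounds, and the source may have more. Where it says the series, first, only, none or still open, it means among the compounds named here.

Working notes on the series. The shared core of compound 1 `CCC(C)NC(=O)/C=C/c1c(/C=C/c2ccc(OC)cc2)cc(OC)cc1OC` carries a sec-butyl amide; compound 2 `COc1ccc(/C=C/c2cc(OC)cc(OC)c2/C=C/C(=O)NC2CC2)cc1` carries a cyclopropyl amide, and compound 3 `COc1ccc(/C=C/c2cc(OC)cc(OC)c2/C=C/C(=O)N2CCN(C)CC2)cc1` a 4-methylpiperazin-1-yl amide. In a functional assay on MCF7 cells (Homo sapiens) for inhibition, read by MTT assay, with a stated time of 48 h (a higher number here means a weaker inhibitor, a lower number a stronger inhibitor), compound 1 gives 3430 nM, compound 2 gives 3940 nM and compound 3 gives 2290 nM. Compound 2 has the highest of the three numbers shown, with compound 1 nearest and compound 3 furthest, yet every step between them stays within the scatter, for instance a 1.1-fold higher number from compound 1 to compound 2 (0.06 log units; within the scatter).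

Compound 4 `COc1ccc(/C=C/c2cc(OC)cc(OC)c2/C=C/C(=O)N2CCCCC2)cc1` is not yet measured. Its difference from compound 2: piperidin-1-yl in place of cyclopropylamino on a carbonyl carbon. Going by the values given here, the steps that bear on it are the two in which a secondary amide gives way to a cyclic tertiary one: a 1.5-fold lower number from compound 1 to compound 3 (0.18 log units; within the scatter) and a 1.7-fold lower number from compound 2 to compound 3 (0.24 log units; within the scatter). Both point toward a lower number without leaving the scatter. The expected step is therefore small and toward a lower number, a 1.4-fold lower number from compound 2 to compound 4 (0.15 log units; within the scatter). Compound 4 is estimated at 2800 nM, with a range of 1400 nM to 5600 nM.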

Compound 4, half-maximal inhibitory concentration: 6050 nM
For compound 4 the middle estimate is 2.2-fold (0.33 log units) below the measured one; measured number outside the range, above it.
By their numbers in this assay, from the lowest: compounds 3, 1, 2 and 4 (each within the scatter of the next, the first and the last beyond it).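

In this assay, going by these compounds alone, this position on the carbonyl carbon separates two cyclic tertiary amides: piperidin-1-yl in place of 4-methylpiperazin-1-yl gives a 2.6-fold higher number from compound 3 to compound 4 (0.42 log units; beyond the scatter), the only step beyond the scatter. Loss of the amide hydrogen therefore does not by itself go with a lower number, as compound 3 and compound 4 both lack it, while a 1.5-fold higher number from compound 2 to compound 4 (0.19 log units; within the scatter) and a 1.8-fold higher number from compound 1 to compound 4 (0.25 log units; within the scatter) stay within the scatter. No measurement available here accounts for the gap between these two rings.

Open, going by these compounds, is whether a morpholin-4-yl or an unsubstituted piperazin-1-yl amide on the same carbonyl carbon would fall nearer compound 3 or compound 4. Also open, on these data alone, is whether the gap depends on the methyl group of the 4-methylpiperazin-1-yl ring or on its second ring nitrogen.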